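Swapping the Ester Chain for an Ether Chain

A few compounds are considered here, and "the series" means these few. Any claim that something is new, unique, unknown or untested is made for them only; others in the source may bear on it.

In a functional assay on FaDu cells (Homo sapiens) for cytotoxicity, read by MTT assay, with a stated time of 72 h (a higher number here means that more compound is tolerated, a lower number that less compound is tolerated), compound 3 `COC(=O)CCn1cc(C(=O)C(=O)Nc2ccc(OC)nc2)c2ccccc21` gives 168 nM. Compound 1 `COc1ncc(NC(=O)C(=O)c2cn(C(C)C)c3ccccc23)cn1` gives 171 nM, within the scatter of compound 3. Compound 2 `COc1ccc(NC(=O)C(=O)c2cn(C(C)(C)COCC(=O)O)c3ccccc23)cn1` gives > 10000 nM, which is a limit of the assay and not a number.

In compound 4 `COCC(C)n1cc(C(=O)C(=O)Nc2ccc(OC)nc2)c2ccccc21`, 1-(methoxymethyl)ethyl stands in place of 2-(methoxycarbonyl)ethyl on an aromatic nitrogen (1-(methoxymethyl)ethyl in place of 2-(methoxycarbonyl)ethyl on an aromatic nitrogen). Both groups carry no net charge.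

Among the measured compounds shown here, only one measured step bears on this place: an at least 59-fold lower number from compound 2 to compound 3 (1.77 log units; beyond the scatter), which is large and beyond the scatter. For the measured compounds named here, it shows that a change on this nitrogen can matter greatly in this assay, but it involves a different group from the one entering compound 4, so it sets no size for this swap. No shift beyond the scatter is therefore expected, and the expected step is a 1.2-fold higher number from compound 3 to compound 4 (0.08 log units; within the scatter). Compound 4 is estimated at 200 nM, with an expected range of 60 nM to 700 nM.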

Compound 4, concentration lethal to 50% of the cells: 12 nM
Compound 4: middle estimate off by 17-fold (1.22 log units), on the high side; the whole stated range lies above it.
By their numbers in this assay, from the lowest: compound 4; then compounds 3 and 1 (each within the scatter of the next). At a limit, above all of these: compound 2.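

In this assay, the swap of chains on this aromatic nitrogen gives a 14-fold lower number from compound 3 to compound 4 (1.15 log units; beyond the scatter), so a large shift arises here between two groups that carry no net charge. Measured against the larger chain of compound 2, the result is an at least 830-fold lower number from compound 2 to compound 4 (2.92 log units; beyond the scatter). The value of compound 2 is a limit of the assay and not a number: the limit of > 10000 nM in this assay, at which 1 of the 4 values shown sits.

The swap removes the ester carbonyl and reshapes the chain in a single step, and the compounds shown do not separate these two changes or say why the number falls. From the compounds shown here alone, how an amine or a nitrile on this chain would read in this assay also stays open.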